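Nitro in place of chloro: an expected step

The compounds below may be only part of what the source reports. "The series", "measured", "known", "first", "only" and "open" are said of these compounds alone.

compound 1 `Nc1nc(N)c2cc(CSC(=S)N3CCN(C4CCCCC4)CC3)ccc2n1` gives 8400 nM
compound 2 `Cc1ccc(N2CCN(C(=S)SCc3ccc4nc(N)nc(N)c4c3)CC2)c(C)c1` gives 4070 nM
compound 3 `Nc1nc(N)c2cc(CSC(=S)N3CCN(c4ccccc4Cl)CC3)ccc2n1` gives 5490 nM

These values come from a functional assay on HCT-116 cells (Homo sapiens) for antiproliferative activity, read by MTT assay, with a stated time of 72 h; on this read-out higher numbers stand for weaker inhibition and lower numbers for stronger inhibition. Compound 3 stands within the scatter of both others: the steps of a 1.5-fold lower number from compound 1 to compound 3 (0.18 log units; within the scatter) and a 1.3-fold higher number from compound 2 to compound 3 (0.13 log units; within the scatter) are small. Only a 2.1-fold lower number from compound 1 to compound 2 (0.31 log units; beyond the scatter) passes the scatter, and modestly. Compound 4 `Nc1nc(N)c2cc(CSC(=S)N3CCN(c4ccccc4[N+](=O)[O-])CC3)ccc2n1` differs from compound 3 by nitro in place of chloro on an aromatic carbon with nitro in place of chloro on an aromatic carbon. For the measured compounds named here, no measured step exchanges these two groups. Going by the values given here, the three changes on the ring amine nitrogen are the only guide, and they suggest no clear shift in this assay in either direction. The expected step is a 1.1-fold lower number from compound 3 to compound 4 (0.04 log units; within the scatter) and no move beyond the scatter is anticipated. Compound 4 is estimated at 5000 nM with 2200 nM to 11000 nM as its expected range.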

Compound 4, half-maximal inhibitory concentration: 5520 nM
Compound 4: the middle estimate sits 1.1-fold (0.04 log units) below what was measured; the measured number falls inside the stated range.
By their numbers in this assay, from the lowest: compounds 2, 3, 4 and 1 (each within the scatter of the next, the first and the last beyond it).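

In this assay, for the compounds shown here, nitro in place of chloro on an aromatic carbon ortho to a large group gives a 1.0-fold higher number from compound 3 to compound 4 (0.00 log units; within the scatter), the first direct reading of this exchange: three heavy atoms and two hydrogen-bond acceptors enter where one chlorine leaves, and the number stays within the scatter. The 2-nitrophenyl compound also stays within the scatter of the other two, with a 1.4-fold higher number from compound 2 to compound 4 (0.13 log units; within the scatter) and a 1.5-fold lower number from compound 1 to compound 4 (0.18 log units; within the scatter). No evidence is at hand on what lies behind these readings.

From the compounds shown here alone, whether an amine or a carboxylic acid on this aromatic carbon would also stay within the scatter remains open. So does whether any group here could move the number beyond it.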